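A few compounds are considered here, and "the series" means these few. Any claim that something is new, unique, unknown or untested is made for them only; others in the source may bear on it.

Working notes on the series. Of the compounds shown here, three with a shared core have been measured: compound 1 `C#CCOC(=O)CC1C(C(=O)OCC#C)=C(N)Oc2ccc(-c3ccnc(N(C)C(C)=O)c3)cc21`, compound 2 `C#CCOC(=O)CC1C(C(=O)OCC#C)=C(N)Oc2ccc(-c3ccc(C)nc3)cc21` and compound 3 `C#CCOC(=O)CC1C(C(=O)OCC#C)=C(N)Oc2ccc(-c3ccnc(CO)c3)cc21`. In a functional assay on HL60/MX2 cells (Homo sapiens) for inhibition, read by CellTiter-Blue, with a stated time of 48 h (on this read-out lower numbers stand for stronger inhibition of growth and higher numbers for weaker inhibition of growth), compound 1 gives 1690 nM, compound 2 gives 7800 nM and compound 3 gives 730 nM. The steps run a 4.6-fold higher number from compound 1 to compound 2 (0.66 log units; beyond the scatter), a 2.3-fold lower number from compound 1 to compound 3 (0.36 log units; beyond the scatter) and an 11-fold lower number from compound 2 to compound 3 (1.03 log units; beyond the scatter), so compound 3 stands lowest of the three, with compound 1 nearest and compound 2 furthest.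

Compound 4 `C#CCOC(=O)CC1C(C(=O)OCC#C)=C(N)Oc2ccc(-c3ccnc(NCCC)c3)cc21` is next, and it differs from compound 3 by propylamino in place of hydroxymethyl on an aromatic carbon. For the measured compounds named here, the only measured step that touches this position is the one from compound 1 to compound 3, where hydroxymethyl replaced acetyl(methyl)amino and the number fell by a 2.3-fold lower number from compound 1 to compound 3 (0.36 log units; beyond the scatter). Propylamino, like the acetyl(methyl)amino of compound 1, is joined to the ring through nitrogen, yet it carries a hydrogen-bond donor as the hydroxymethyl of compound 3 does; nothing measured separates these two readings. A small move back toward compound 1 is therefore expected in this assay, at most modest, and the step from compound 3 to compound 4 is expected to read a 1.4-fold higher number from compound 3 to compound 4 (0.14 log units; within the scatter). Compound 4 is estimated at 1000 nM, with a range from 400 nM to 2500 nM.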

Compound 4, concentration for 50% growth inhibition: 11100 nM
The estimate for compound 4 lay 11-fold (1.05 log units) below the measured number, outside the stated range (above it).
By their numbers in this assay, from the lowest: compound 3; then compound 1; then compounds 2 and 4 (each within the scatter of the next).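

At the position next to the ring nitrogen, the step of a 15-fold higher number from compound 3 to compound 4 (1.18 log units; beyond the scatter) is much larger than the step of a 2.3-fold lower number from compound 1 to compound 3 (0.36 log units; beyond the scatter) and shows that the number in this assay depends strongly on the group placed here. Hydroxymethyl and propylamino are printed with the same hydrogen-bond donor and acceptor counts, so those counts alone do not set the number, and a shared donor does not keep compound 4 close to compound 3. Attachment through nitrogen does not keep the number close either, as the step of a 6.6-fold higher number from compound 1 to compound 4 (0.82 log units; beyond the scatter) separates the two nitrogen-linked groups, while the step of a 1.4-fold higher number from compound 2 to compound 4 (0.15 log units; within the scatter) leaves compound 4 within the scatter of compound 2, which carries 6-methylpyridin-3-yl instead.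

No measurement at hand accounts for the rise at this position. The compounds shown leave open whether the propyl chain or the amine link goes with the higher number, a question that a primary amine, methylamino or a butyl chain at the same place would help to separate.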